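Replacing a Small Amine with a Larger Amide Arm

The compounds below may be only part of what the source reports. "The series", "measured", "known", "first", "only" and "open" are said of these compounds alone.

Of the compounds shown here, three sharing one core have been measured in an assay for inhibition of Suppressor of tumorigenicity 14 protein (Homo sapiens), read by fluorescence; on this read-out lower numbers stand for stronger inhibition and higher numbers for weaker inhibition. Compound 1 `N=C(N)c1ccc(Oc2ccc(NS(=O)(=O)c3ccc(F)cc3)c(Oc3ccc(C(=N)N)cc3)n2)cc1` gives 200 nM, compound 2 `N=C(N)c1ccc(Oc2ccc(C(=O)N[C@H]3CC[C@H](N)CC3)c(Oc3ccc(C(=N)N)cc3)n2)cc1` gives 500 nM, and compound 3 `N=C(N)c1ccc(Oc2ccc(N)c(Oc3ccc(C(=N)N)cc3)n2)cc1` gives 2900 nM, the highest of the three numbers and thus the weakest inhibitor among them.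

The next compound, compound 4 `N=C(N)c1ccc(Oc2ccc(C(=O)N3CCC(CCN)CC3)c(Oc3ccc(C(=N)N)cc3)n2)cc1`, differs from compound 3 in one place: (4-(2-aminoethyl)piperidin-1-yl)carbonyl in place of amino on an aromatic carbon. Going by the values given here, two measured steps bear on this. Going from compound 2 to compound 3 was a 5.8-fold higher number from compound 2 to compound 3 (0.76 log units; beyond the scatter), so removing a large carbamoyl arm and leaving only an amino group weakened binding. Going from compound 1 to compound 3 was a 15-fold higher number from compound 1 to compound 3 (1.16 log units; beyond the scatter), again a large group giving way to a bare hydrogen. Compound 4 reverses this pattern by putting a large carbonyl-linked arm back in place of the amino group, so a step toward stronger inhibition, of a size close to the step between compound 2 and compound 3, is expected in this assay. Compound 4 is therefore estimated at 600 nM, with a range from 200 nM to 1800 nM. That estimate implies a 4.8-fold lower number from compound 3 to compound 4 (0.68 log units; beyond the scatter).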

Compound 4, inhibition constant: 200 nM
Compound 4: middle estimate off by 3.0-fold (0.48 log units), on the high side; low and high end bracket the measured number.
By their numbers in this assay, from the lowest: compounds 1 and 4 (each within the scatter of the next); then compound 2; then compound 3.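

In this assay, (4-(2-aminoethyl)piperidin-1-yl)carbonyl in place of amino gives a 15-fold lower number from compound 3 to compound 4 (1.16 log units; beyond the scatter) and so shows that this position, para to a large group, accepts a far bigger group than amino with a clear gain. Changing only what sits on the carbonyl carbon gives a 2.5-fold lower number from compound 2 to compound 4 (0.40 log units; beyond the scatter) and shows that the number depends on the arm beyond the carbonyl, not on the carbonyl alone. A differently built arm, ((4-fluorophenyl)sulfonyl)amino, gives no change at the digits printed from compound 1 to compound 4 (within the scatter) and so shows that an amide link is not the only route to this level.

On these data alone, whether the amine at the end of the arm matters stays open, and an arm ending in a hydroxyl group or a carboxylic acid, or one with a longer chain than aminoethyl, would test it. Nothing available explains why these arms differ.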